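The compounds below may be only part of what the source reports. "The series", "measured", "known", "first", "only" and "open" are said of these compounds alone.

Three compounds with a shared core have been followed so far. For compound 1 `CC(C)C(NS(=O)(=O)c1ccc(Br)cc1)C1=CC(=O)c2c(O)ccc(O)c2C1=O`, the entry reads "not determined" (no result reported). In a functional assay on HL-60 cells (Homo sapiens) for cytotoxicity, read by MTT assay (a higher number here means a weaker inhibitor, a lower number a stronger inhibitor), compound 2 `COc1ccc(S(=O)(=O)NC(C)C2=CC(=O)c3c(O)ccc(O)c3C2=O)c(OC)c1` gives 500 nM, and compound 3 `CC(NS(=O)(=O)c1ccc(F)cc1)C1=CC(=O)c2c(O)ccc(O)c2C1=O` gives 90 nM. Compound 3 therefore holds the lower of the two available numbers, the stronger result in this assay.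

Compound 4 `CC(NS(=O)(=O)c1ccc(Br)cc1)C1=CC(=O)c2c(O)ccc(O)c2C1=O` departs from compound 3 in one place: bromo in place of fluoro on an aromatic carbon. This puts bromo in place of fluoro on an aromatic carbon, para to a large group.

Among the compounds with values here, only one measured step bears on this exchange, and only indirectly: a 5.6-fold lower number from compound 2 to compound 3 (0.74 log units; beyond the scatter). That modest step replaced 2,4-dimethoxyphenyl with 4-fluorophenyl on the sulfonyl sulfur, so it touches the same part of the molecule but is a different change. Within the data shown here, no measured pair exchanges fluoro for bromo. Compound 1 also carries the 4-bromophenyl group, but it supplies no number to compare.

Since the new change is narrower than the measured one, a smaller shift is expected, with no clear direction beyond the scatter. The expected step is a 1.3-fold higher number from compound 3 to compound 4 (0.12 log units; within the scatter). Compound 4 is estimated at 120 nM, with an expected range of 40 nM to 350 nM.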

Compound 4, half-maximal inhibitory concentration: 100 nM
Beside the measured number, compound 4's estimate is 1.2-fold (0.08 log units) above it; the measured number falls inside the stated range.
By their numbers in this assay, from the lowest: compounds 3 and 4 (each within the scatter of the next); then compound 2.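

In this assay, within the data shown here, exchanging fluoro for bromo on an aromatic carbon, para to a large group, gives a 1.1-fold higher number from compound 3 to compound 4 (0.05 log units; within the scatter) and thus no step that can be told from the scatter, which is the first direct reading of this exchange. Compared with the 2,4-dimethoxyphenyl group, the 4-bromophenyl group gives a 5.0-fold lower number from compound 2 to compound 4 (0.70 log units; beyond the scatter) while the 4-fluorophenyl group gives a 5.6-fold lower number from compound 2 to compound 3 (0.74 log units; beyond the scatter) so among these three compounds, the step away from compound 2 appears with both halogens and neither compound goes against it. Nothing available here accounts for why the two halogens read alike.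

The compounds shown leave open whether an amine, a nitrile or a carboxylic acid in place of the halogen on this aromatic carbon would stay with compound 3 and compound 4 or fall nearer compound 2. As far as these compounds go, compound 1 shares the 4-bromophenyl group with compound 4, but any step involving compound 1 cannot be read, so what its isopropyl group does alongside that 4-bromophenyl group also remains open.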